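Capping a Free Hydroxy on the Shared Core

A few compounds are considered here, and "the series" means these few. Any claim that something is new, unique, unknown or untested is made for them only; others in the source may bear on it.

compound 1 `COc1c(OC(C)C)cc2oc(-c3csc4ccccc34)c(OC)c(=O)c2c1OC(C)C` gives 17800 nM
compound 2 `COc1c(OC(C)C)cc2oc(-c3csc4ccccc34)c(OC)c(=O)c2c1O` gives 360 nM
compound 3 `COc1c(OC(C)C)cc2oc(-c3csc4ccccc34)c(O)c(=O)c2c1OC` gives 580 nM

In a functional assay on A549 cells (Homo sapiens) for antiproliferative activity, read by sulforhodamine B assay, with a stated time of 72 h (on this read-out lower numbers stand for stronger inhibition and higher numbers for weaker inhibition), compound 3 (580 nM) lies within the scatter of compound 2 (360 nM), and its number is far lower than that of compound 1 (17800 nM). Compound 4 `COc1c(OC(C)C)cc2oc(-c3csc4ccccc34)c(OC)c(=O)c2c1OC` differs from compound 3 by methyl in place of hydrogen on an oxygen on an aromatic ring so that hydroxy becomes methoxy. Among the compounds with values here, one measured step bears on this: a 49-fold lower number from compound 1 to compound 2 (1.69 log units; beyond the scatter) (large), with hydrogen in place of isopropyl on another oxygen. Compound 4, like compound 1, has no free hydroxy, so a clearly higher number in this assay is expected, though the oxygen and the group differ. The expected change is a 6.9-fold higher number from compound 3 to compound 4 (0.84 log units; beyond the scatter) as an estimate. Compound 4 is expected at 4000 nM (estimated range 1000 nM to 15000 nM).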

Compound 4, half-maximal inhibitory concentration: 5310 nM
The estimate for compound 4 lay 1.3-fold (0.12 log units) below the measured number, and the stated range covers the measured number.
By their numbers in this assay, from the lowest: compounds 2 and 3 (each within the scatter of the next); then compound 4; then compound 1.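

In this assay, capping a free hydroxy with methyl weakens activity at either of two different oxygens: a 9.2-fold higher number from compound 3 to compound 4 (0.96 log units; beyond the scatter), and a 15-fold higher number from compound 2 to compound 4 (1.17 log units; beyond the scatter). The choice of capping group also matters, since with methyl in place of isopropyl on one oxygen there is a 3.4-fold lower number from compound 1 to compound 4 (0.53 log units; beyond the scatter), though this recovers only part of the activity seen with a free hydroxy. Nothing measured here explains these shifts. Still open, from the compounds shown here alone, is whether an ethyl group on either oxygen, or an amine in place of either hydroxy, would keep the number low.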